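Ethyl for methyl on the ring nitrogen: tolerance in macrophages

The source may hold more compounds than are shown below. What is called first, only, known or untested is meant among the compounds shown, and "the series" means these compounds.

Compound 1 `CC1=CC(=O)/C(=C(/C)Nc2ccc3c(Cl)nn(C)c3c2)C(=O)O1`, compound 2 `CCn1nc(Cl)c2ccc(N/C(C)=C3\C(=O)C=C(C)OC3=O)cc21` and compound 3 `CC1=CC(=O)/C(=C(/C)Nc2ccc3c(Cl)n(C)nc3c2)C(=O)O1` share the same enone side chain on two differently joined cores. In an ADME assay on RAW264.7 cells (Mus musculus) for cytotoxicity, read by resazurin assay, with a stated time of 48 h (a higher number here means that more compound is tolerated, a lower number that less compound is tolerated), compound 1 gives > 100000 nM, which is a limit of the assay rather than a number. Compound 2 gives 6230 nM in this assay, and compound 3 gives 6260 nM, with compound 2 and compound 3 sitting together within the scatter. The change methyl in place of hydrogen on a saturated chain carbon bound to an aromatic nitrogen produced an at least 16-fold lower number from compound 1 to compound 2 (1.20 log units; beyond the scatter); the limit of > 100000 nM in this assay, at which 1 of the 3 values shown sits, means only a lower bound of that step is known. How the core of compound 3 differs from the core of compound 1 is not broken down here.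

Compound 4 `CCn1nc2cc(N/C(C)=C3\C(=O)C=C(C)OC3=O)ccc2c1Cl` carries the same change, (methyl in place of hydrogen on a saturated chain carbon bound to an aromatic nitrogen), on the core of compound 3. Since the step from compound 1 to compound 2 was an at least 16-fold lower number from compound 1 to compound 2 (1.20 log units; beyond the scatter), a step of comparable direction is expected, though its size rests on a single pair of which one value is a limit, so the expected step from compound 3 to compound 4 is a 6.3-fold lower number from compound 3 to compound 4 (0.80 log units; beyond the scatter). Compound 4 is expected to give 1000 nM in this assay. The expected range for compound 4 runs from 200 nM to 6000 nM.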

Compound 4, half-maximal cytotoxic concentration: 6250 nM
Compound 4: the middle estimate sits 6.3-fold (0.80 log units) below what was measured; measured number outside the range, above it.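

On the core of compound 3, the change methyl to ethyl gives a 1.0-fold lower number from compound 3 to compound 4 (0.00 log units; within the scatter), so in this assay the step seen on the core of compound 1 does not carry over to this second core, and the two steps differ: the same change on two cores in this assay, an at least 16-fold lower number (1.20 log units; beyond the scatter) from compound 1 to compound 2 and a 1.0-fold lower number (0.00 log units; within the scatter) from compound 3 to compound 4, at least 16-fold (1.20 log units) apart, beyond the scatter of two such steps

Compound 1 stands at > 100000 nM, which is a limit of the assay and not a number. The earlier step and the gap between the two steps are therefore known only as lower bounds, and a single pair on each core shows neither why the outcomes part nor which core is more typical of the series: the limit of > 100000 nM in this assay, at which 1 of the 4 values shown sits.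

On these data alone, it remains open whether a longer chain such as propyl, or a chain ending in an amine or a carboxylic acid, would follow the pattern of the core of compound 1 or that of the core of compound 3. Also open, as far as these compounds go, is how either core behaves in this assay with a hydrogen in place of the methyl on the ring nitrogen.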